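The compounds below may be only part of what the source reports. "The series", "measured", "known", "first", "only" and "open" are said of these compounds alone.

Working notes on the series. Two compounds have numbers in a functional assay on NCI-H1581 cells (Homo sapiens) for inhibition, read by MTT assay, with a stated time of 48 h, tested at 10 uM; on this read-out higher numbers stand for more inhibition at the one concentration tested (going by the name of the read-out) and lower numbers for less inhibition. Compound 1 `COc1cc(Br)ccc1Nc1cc(NC(=O)Nc2c(Cl)cccc2Cl)ncn1` gives 47.3% in this assay, and compound 2 `COc1ccc(Br)cc1Nc1cc(NC(=O)Nc2c(Cl)cccc2Cl)ncn1` gives 53.3% in this assay. The one measured step, a number 6 percentage points higher from compound 1 to compound 2 (within the scatter), exchanges 4-bromo-2-methoxyphenyl for 5-bromo-2-methoxyphenyl on a nitrogen on an aromatic ring and lies within the scatter, so compound 2 and compound 1 stand within the scatter of each other on the numbers shown.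

Compound 3 `COc1ccc(OC)c(Nc2cc(NC(=O)Nc3c(Cl)cccc3Cl)ncn2)c1` is not yet measured. It differs from compound 2 by methoxy in place of bromo on an aromatic carbon. Within the data shown here, no measured step exchanges bromo for methoxy, so the only guide is that the bromo exchange between compound 1 and compound 2 gave nothing beyond the scatter; a step of similar size, with no clear direction, is expected here. The step expected in this assay is a number 6.3 percentage points lower from compound 2 to compound 3 (within the scatter). Compound 3 is estimated at 47% in this assay, within a range from 27% to 67%.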

Compound 3, a percentage reported as inhibition, at one concentration (the size of the read-out at that concentration, not a potency): 93.1%
Estimate against measurement, compound 3: 46.1 percentage points below, outside the stated range (above it).
By their numbers in this assay, from the lowest: compounds 1 and 2 (each within the scatter of the next); then compound 3.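

In this assay the exchange of bromo for methoxy on an aromatic carbon, para to a methoxy group, gives a number 39.8 percentage points higher from compound 2 to compound 3 (beyond the scatter) as the only step of this kind in the series. The earlier step, a number 6 percentage points higher from compound 1 to compound 2 (within the scatter) and moving bromo on the ring, left the two numbers within the scatter of each other, whereas this step shows that the group on this carbon can shift the read-out beyond the scatter. No measurement at hand bears on why the number rises.

As far as these compounds go, it remains open whether the rise belongs to methoxy itself or to the loss of bromo, since it rests on a single pair of compounds. Hydrogen, ethoxy or an amine on the same carbon would separate those two readings.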